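Swapping Methyl for Dimethylamino on Compound 2

The source may hold more compounds than are shown below. What is called first, only, known or untested is meant among the compounds shown, and "the series" means these compounds.

Compound 1 `COc1cc2nc(N3CCN(c4ccccc4)CC3)cc(N)c2cc1OC`: 1.72 nM
Compound 2 `COc1cc2nc(N3CCN(c4nccc(C)n4)CC3)cc(N)c2cc1OC`: 0.63 nM

In an assay on brain for displacement of a labelled ligand from Adrenergic receptor alpha-1 (Rattus norvegicus) (on this read-out higher numbers stand for weaker inhibition and lower numbers for stronger inhibition), compound 2 stands at the lowest of the two numbers; its nearest neighbour is compound 1, the gap being a 2.7-fold lower number from compound 1 to compound 2 (0.44 log units; beyond the scatter). Compound 3 `COc1cc2nc(N3CCN(c4nccc(N(C)C)n4)CC3)cc(N)c2cc1OC` is not yet measured. It differs from compound 2 in one place: dimethylamino in place of methyl on an aromatic carbon. Among the measured compounds shown here, no measured step touches this change; the one step seen, a 2.7-fold lower number from compound 1 to compound 2 (0.44 log units; beyond the scatter), concerns a different group on the amine nitrogen in a ring. With nothing to rest on, no step beyond the scatter is assumed. Compound 3 is expected to give 0.7 nM in this assay, between 0.25 nM and 2 nM. That estimate means a 1.1-fold higher number from compound 2 to compound 3 (0.05 log units; within the scatter).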

Compound 3, inhibition constant: 0.46 nM
Beside the measured number, compound 3's estimate is 1.5-fold (0.18 log units) above it; low and high end bracket the measured number.
By their numbers in this assay, from the lowest: compounds 3 and 2 (each within the scatter of the next); then compound 1.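

At this aromatic carbon, in this assay, dimethylamino in place of methyl gives a 1.4-fold lower number from compound 2 to compound 3 (0.14 log units; within the scatter), so the position accepts a group with more heavy atoms and no step beyond the scatter appears. The 4-(dimethylamino)pyrimidin-2-yl group also holds the advantage over phenyl, with a 3.7-fold lower number from compound 1 to compound 3 (0.57 log units; beyond the scatter). Nothing available explains why methyl and dimethylamino give such close numbers here. Still open, from the compounds shown here alone, is how far this tolerance extends: a morpholine ring, a carboxylic acid or a longer chain at this same carbon could give quite different numbers.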